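A Bulkier Amine Enters the Side Chain of Compound 2

The compounds below may be only part of what the source reports. "The series", "measured", "known", "first", "only" and "open" are said of these compounds alone.

Of the compounds shown here, two have been tested in a functional assay on MCF7 cells (Homo sapiens) for antiproliferative activity; a higher number here means a weaker inhibitor, a lower number a stronger inhibitor. Compound 1 `CC(=O)Oc1ccc(C(=O)Nc2cc3ccc(OCC4CCCNC4)c(C)c3oc2=O)cc1CC=C(C)C` gives 820 nM. For the measured compounds named here, compound 2 `CC(C)=CCc1cc(C(=O)Nc2cc3ccc(OCCCN(C(C)C)C(C)C)c(C)c3oc2=O)ccc1O` gives 1310 nM, the highest of the two numbers so far, though its gap to compound 1 lies within the usual scatter. Compound 3 `CC(C)=CCc1cc(C(=O)Nc2cc3ccc(OCCCNC(C)(C)c4ccccc4)c(C)c3oc2=O)ccc1O` has not yet been measured. It differs from compound 2 in one place: (1-methyl-1-phenylethyl)amino in place of diisopropylamino on a saturated chain carbon, three bonds along the chain from an oxygen on an aromatic ring. Going by the values given here, no measured pair shows this change, so only a modest step in either direction, or none beyond the scatter, is expected. The value of compound 3 in this assay is estimated at 900 nM, within a range from 300 nM to 3000 nM, an expected step of a 1.5-fold lower number from compound 2 to compound 3 (0.16 log units; within the scatter).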

Compound 3, half-maximal inhibitory concentration: 1070 nM
Compound 3: middle estimate off by 1.2-fold (0.08 log units), on the low side; low and high end bracket the measured number.
By their numbers in this assay, from the lowest: compounds 1, 3 and 2 (each within the scatter of the next).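

In this assay, putting (1-methyl-1-phenylethyl)amino in place of diisopropylamino gives a 1.2-fold lower number from compound 2 to compound 3 (0.09 log units; within the scatter) at this saturated chain carbon, three bonds along the chain from an oxygen on an aromatic ring. A six-membered aromatic ring and a hydrogen-bond donor thus enter at this position without a change beyond the scatter. As far as these compounds go, whether a primary amine, a carboxylic acid or a longer chain would move the number beyond the scatter remains open. No measurement shown explains why this swap leaves the number within the scatter.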